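Swapping Methyl for Trifluoromethyl in Compound 4

A few compounds are considered here, and "the series" means these few. Any claim that something is new, unique, unknown or untested is made for them only; others in the source may bear on it.

Compound 3 `Cc1ccc(Nc2nc(N)nc(COc3cc(N4CCCC4=O)ccc3C)n2)cc1Cl` gives 7450 nM in an assay on COS-7 cells for agonist activity at Free fatty acid receptor 1 (Homo sapiens), read by scintillation counting and inositol phosphate accumulation, with a stated time of 90 min (on this read-out lower numbers stand for an effect already at smaller amounts and higher numbers for an effect only at larger amounts of compound), the highest of the two numbers at hand. Its nearest neighbour is compound 1 `Cc1ccc(Nc2nc(N)nc(COc3cccc(N4CCCC4=O)c3)n2)cc1Cl`, and in this assay compound 1 gives 820 nM, and compound 2 `Cc1ccc(Nc2nc(N)nc(COc3cc(N4CCCC4=O)ccc3Cl)n2)cc1Cl` gives "not determined" (no result reported). For the measured compounds named here, the one measured step, a 9.1-fold higher number from compound 1 to compound 3 (0.96 log units; beyond the scatter), came with methyl in place of hydrogen on an aromatic carbon. Compound 4 `Cc1ccc(Nc2nc(N)nc(COc3cc(N4CCCC4=O)ccc3C(F)(F)F)n2)cc1Cl` carries trifluoromethyl in place of methyl on an aromatic carbon. Going by the values given here, no measured step covers this exchange; the only step of this kind, from compound 1 to compound 3, was modest. The step of a 1.1-fold lower number from compound 3 to compound 4 (0.03 log units; within the scatter) is therefore expected to stay small, with no clear direction beyond the scatter. Compound 4 is estimated at 7000 nM, within 2000 nM to 25000 nM.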

Compound 4, half-maximal effective concentration: 20100 nM
Estimate against measurement, compound 4: 2.9-fold (0.46 log units) below, within the range that was stated.
By their numbers in this assay, from the lowest: compound 1; then compound 3; then compound 4.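

In this assay trifluoromethyl, on the aromatic carbon para to a 2-oxopyrrolidin-1-yl group, does not recover what methyl lost: the exchange gives a 2.7-fold higher number from compound 3 to compound 4 (0.43 log units; beyond the scatter) and shows that the number depends on which group sits here, not only on whether hydrogen is replaced. Against hydrogen, the change gives a 25-fold higher number from compound 1 to compound 4 (1.39 log units; beyond the scatter) and marks the largest step seen at this position. No measured evidence at hand accounts for this order.

The compounds shown leave open whether a methoxy group, an amine or a single fluorine here would come closer to compound 1 or move further from it.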